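From nitro to chloro: compound 3 to compound 4

A few compounds are considered here, and "the series" means these few. Any claim that something is new, unique, unknown or untested is made for them only; others in the source may bear on it.

compound 1 `COc1ccc(Cc2nnc(NC(=O)/C(C#N)=C/c3ccccc3OS(=O)(=O)c3ccc(Cl)cc3)s2)cc1`: 34%
compound 2 `Cc1ccc(S(=O)(=O)Oc2ccccc2/C=C(\C#N)C(=O)Nc2nnc(Cc3ccc(F)cc3)s2)cc1`: 16%
compound 3 `N#C/C(=C\c1ccccc1OS(=O)(=O)c1ccc([N+](=O)[O-])cc1)C(=O)Nc1nnc(Cc2ccc(F)cc2)s1`: 8%

In an ADME assay on HEK-293T cells (Homo sapiens) for inhibition, read by CCK-8 assay, with a stated time of 48 h, tested at 20 uM (on this read-out lower numbers stand for less inhibition of growth and higher numbers for more inhibition of growth at the one concentration tested), compound 3 gives 8%, which lies within the scatter of compound 2 at 16%. Compound 1 gives 34%, a number beyond the scatter of compound 3.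

Compound 4 `N#C/C(=C\c1ccccc1OS(=O)(=O)c1ccc(Cl)cc1)C(=O)Nc1nnc(Cc2ccc(F)cc2)s1` differs from compound 3 in one place: chloro in place of nitro on an aromatic carbon. Put simply, this is chloro in place of nitro on an aromatic carbon, turning 4-nitrophenyl into 4-chlorophenyl.

One measured step changes this same place: a number 8 percentage points lower from compound 2 to compound 3 (within the scatter), with nitro in place of methyl. That small step suggests little movement here as well. Compound 1 carries the same 4-chlorophenyl group and gives 34%, but it also differs from compound 4 elsewhere, so it is only a loose hint towards a higher number. The expected change is a number 8 percentage points higher from compound 3 to compound 4 (within the scatter), an estimated small rise that would not clear the scatter. For compound 4 the estimate is 16%, with an expected range from 5% to 32%.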

Compound 4, percent growth inhibition at one concentration: 6%
The estimate for compound 4 lay 10 percentage points above the measured number, within the range that was stated.
By their numbers in this assay, from the lowest: compounds 4, 3 and 2 (each within the scatter of the next); then compound 1.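

In this assay, exchanging nitro, methyl and chloro on this aromatic carbon barely registers, with a number 2 percentage points lower from compound 3 to compound 4 (within the scatter) and a number 10 percentage points lower from compound 2 to compound 4 (within the scatter). Compound 4 carries the same 4-chlorophenyl group as compound 1, yet the step is a number 28 percentage points lower from compound 1 to compound 4 (beyond the scatter), with fluoro in place of methoxy on an aromatic carbon, so the higher number goes with that other place and not with chloro. Nothing measured here explains why these numbers fall as they do.

On these data alone, whether an amine or a carboxylic acid on this same aromatic carbon would stay as flat remains open. As far as these compounds go, it is also open whether nitro or methyl here would give a number like that of compound 1 when paired with its methoxy group.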